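Swapping 1H-pyrazol-1-yl for 1H-pyrrol-1-yl in compound 2

The source may hold more compounds than are shown below. What is called first, only, known or untested is meant among the compounds shown, and "the series" means these compounds.

In a physicochemical assay for lipophilicity, at pH 7.4 (on this read-out higher numbers stand for higher lipophilicity and lower numbers for lower lipophilicity), compound 1 `CCOc1cc(Cl)c(C(=O)NC(=O)Nc2nc3ccc(CN4CCN(C)CC4)cc3s2)cc1N1CCCC1` gives 4 and compound 2 `CCOc1cc(Cl)c(C(=O)NC(=O)Nc2nc3ccc(CN4CCN(C)CC4)cc3s2)cc1-n1cccn1` gives 3.8. These two values lie within the usual scatter of each other, so compound 2 cannot be set apart from compound 1. Compound 3 `CCOc1cc(Cl)c(C(=O)NC(=O)Nc2nc3ccc(CN4CCN(C)CC4)cc3s2)cc1-n1cccc1` has not yet been measured. Its structure differs from that of compound 2 as follows: 1H-pyrrol-1-yl in place of 1H-pyrazol-1-yl on an aromatic carbon. The exchange is on an aromatic carbon, ortho to an ethoxy group and para to a chloro group. Within the data shown here, only one measured step bears on it, a number 0.20 log units lower from compound 1 to compound 2 (within the scatter), which concerns the same aromatic carbon but a different exchange, so the data hold no direct measure of this one. A modest upward step in this assay is nevertheless expected, namely a number 0.40 log units higher from compound 2 to compound 3 (beyond the scatter). For compound 3 the estimated value is 4.2, with an expected range from 3.9 to 4.5.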

Compound 3, distribution coefficient: 4
The estimate for compound 3 lay 0.20 log units above the measured number, within the range that was stated.
By their numbers in this assay, from the lowest: compounds 2, 1 and 3 (each within the scatter of the next).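

In this assay, putting 1H-pyrrol-1-yl in place of 1H-pyrazol-1-yl gave a number 0.20 log units higher from compound 2 to compound 3 (within the scatter), so this exchange of a ring nitrogen for carbon does not separate the two five-membered aromatic rings on this read-out. The comparison with pyrrolidin-1-yl gave no change at the digits printed from compound 1 to compound 3 (within the scatter), so all three groups on this aromatic carbon, ortho to an ethoxy group and para to a chloro group, now lie within the scatter of one another. Nothing available offers an explanation for how close these values lie.

On these data alone, it remains open whether a group of another kind on this carbon, such as a carboxylic acid or a primary amine, would move the number beyond the scatter. As far as these compounds go, it is also open whether these three groups would still read alike with a longer chain in place of the ethoxy group.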